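The source may report more compounds than this note shows. Statements on the series, on what has been measured and on what is new or still open speak of the compounds shown alone.

Working notes on the series. In a functional assay on VCaP cells (Homo sapiens) for antiproliferative activity, read by propidium iodide staining, with a stated time of 96 h (a higher number here means a weaker inhibitor, a lower number a stronger inhibitor), compound 1 (`CC(O)(CSc1ccccc1OC(F)(F)F)C(=O)Nc1cccc(S(F)(F)(F)(F)F)c1`) gives 12600 nM. In this assay compound 2 (`CC(O)(COc1ccc(C(F)(F)F)cc1)C(=O)Nc1cccc(S(F)(F)(F)(F)F)c1`) gives 13300 nM, which lies within the scatter of the value of compound 1, so the two numbers cannot be ranked. Compound 3 (`CC(O)(COc1ccc(C#N)cc1)C(=O)Nc1cccc(S(F)(F)(F)(F)F)c1`) is still unmeasured. It carries cyano in place of trifluoromethyl on an aromatic carbon, para to a large group, which turns 4-(trifluoromethyl)phenyl into 4-cyanophenyl (cyano in place of trifluoromethyl on an aromatic carbon). Among the measured compounds shown here, no measured pair shows a change at this place, so the size of the step has no direct precedent here. The working expectation in this assay is therefore a step within the scatter, with no favoured direction. The expected step is a 1.1-fold higher number from compound 2 to compound 3 (0.05 log units; within the scatter). For compound 3 the estimated value is 15000 nM, with an expected range of 6000 nM to 35000 nM.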

Compound 3, half-maximal inhibitory concentration: 26600 nM
Compound 3: middle estimate off by 1.8-fold (0.25 log units), on the low side; low and high end bracket the measured number.
By their numbers in this assay, from the lowest: compounds 1, 2 and 3 (each within the scatter of the next, the first and the last beyond it).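

In this assay, among the compounds shown here, this is the first step read at this place: cyano in place of trifluoromethyl on an aromatic carbon, para to a large group, gives a 2.0-fold higher number from compound 2 to compound 3 (0.30 log units; within the scatter). Trifluoromethyl, with 4 heavy atoms and 0 hydrogen-bond acceptors, can therefore give way to cyano, with 2 heavy atoms and 1 hydrogen-bond acceptor, and the step still stays within the scatter in this pair. No measurement at hand accounts for the size or direction of this step.

The compounds shown leave open whether an amine or a methoxy group on this aromatic carbon would carry the number beyond the scatter. A single pair also cannot show whether the same exchange gives a similar step on another core.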